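Threonine-to-glycine trim on the quinone amino acid side chain

The source may report more compounds than this note shows. Statements on the series, on what has been measured and on what is new or still open speak of the compounds shown alone.

Compound 1 `C=C1[C@H](C)CCC[C@]1(C)CC/C(C)=C/CC1=C(O)C(=O)C=C(N[C@@H](C(=O)O)[C@H](C)O)C1=O` is measured in an ADME assay on L1210 cells (Mus musculus) for cytotoxicity, with a stated time of 48 h (on this read-out higher numbers stand for weaker inhibition and lower numbers for stronger inhibition), where compound 1 gives 4.6 ug/mL. Compound 2 `COC1=CC(=O)C(O)=C(C/C=C(\C)CC[C@@]2(C)CCC=C(C)[C@H]2C)C1=O` gives 2 ug/mL in this assay, the lower of the two numbers. Compound 3 `CC1=CCC[C@](C)(CC/C(C)=C/CC2=C(O)C(=O)C=C(N[C@@H](C(=O)O)[C@H](C)O)C2=O)[C@@H]1C` reaches only the limit > 10 ug/mL in this assay; that limit is described by the limit of > 10 ug/mL in this assay, at which 1 of the 3 values shown sits. Among the two numbers, compound 1 thus stands highest, with compound 2 the nearest at a gap beyond the scatter.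

Compound 4 `C=C1[C@H](C)CCC[C@]1(C)CC/C(C)=C/CC1=C(O)C(=O)C=C(NCC(=O)O)C1=O` is not yet measured. It differs from compound 1 by hydrogen in place of 1-hydroxyethyl on a saturated chain carbon bound to an amine nitrogen and a carbonyl carbon, so the (1-carboxy-2-hydroxypropyl)amino of compound 1 becomes (carboxymethyl)amino.

Neither measured step touches this part of the molecule. The step of an at least 2.1-fold higher number from compound 1 to compound 3 (0.33 log units; beyond the scatter) changes the six-membered ring; the step of an at least 5.0-fold higher number from compound 2 to compound 3 (0.69 log units; beyond the scatter) swaps methoxy for the whole (1-carboxy-2-hydroxypropyl)amino group. Both show that this assay responds to changes in this series, but neither tells how the 1-hydroxyethyl alone matters. For the measured compounds named here, with no direct precedent, the expectation for the step of a 1.1-fold higher number from compound 1 to compound 4 (0.04 log units; within the scatter) is a small one, in either direction, not clearly beyond the scatter.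

Compound 4 is therefore estimated at 5 ug/mL in this assay, expected to fall between 2 ug/mL and 12 ug/mL.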

Compound 4, half-maximal inhibitory concentration: 4 ug/mL
The estimate for compound 4 lay 1.3-fold (0.10 log units) above the measured number, within the range that was stated.
By their numbers in this assay, from the lowest: compounds 2, 4 and 1 (each within the scatter of the next, the first and the last beyond it). At a limit, above all of these: compound 3.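

In this assay the trim of 1-hydroxyethyl to hydrogen gives a 1.2-fold lower number from compound 1 to compound 4 (0.06 log units; within the scatter) on the core of compound 1, so the read-out does not separate (1-carboxy-2-hydroxypropyl)amino from (carboxymethyl)amino. The earlier replacement of methoxy, an at least 5.0-fold higher number from compound 2 to compound 3 (0.69 log units; beyond the scatter) in the same assay, exchanged the whole amino acid group at once, whereas this pair isolates the 1-hydroxyethyl with its defined stereocentre and shows that the number of compound 1 does not depend on that group.

Other groups on the saturated chain carbon bound to the amine nitrogen and the carbonyl carbon remain open, such as a methyl, a longer chain or a primary amine, as does a methyl ester in place of the carboxylic acid. On these data alone, compound 3 carries the other six-membered ring and its > 10 ug/mL is a limit, so the same trim on that ring also remains open.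

The data shown give no reason for the absence of a change beyond the scatter at this position.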